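Removing the chloro from a chalcone-type thiazole series

This account rests on a few compounds, and the source may have more. Where it says the series, first, only, none or still open, it means among the compounds named here.

Compound 1, `Cc1ccc(Nc2nc(C)c(C(=O)/C=C/c3ccc(Cl)cc3)s2)cc1`, in a functional assay on BGC-823 cells (Homo sapiens) for cytotoxicity, read by MTT assay (a lower number here means a stronger inhibitor, a higher number a weaker inhibitor), gives > 25000 nM, which is a limit of the assay and not a number.
Compound 2, `Cc1nc(Nc2cccc(Cl)c2)sc1C(=O)/C=C/c1ccc(Cl)cc1`, gives > 25000 nM, again a limit.
Compound 3, `Cc1cccc(Nc2nc(C)c(C(=O)/C=C/c3ccc(Cl)cc3)s2)c1`, gives > 25000 nM, also a limit.

Compound 1 therefore stands at the limit, where all three measured values sit: the limit of > 25000 nM in this assay, at which 3 of the 3 values shown sit. The three measured steps, a step that the two limits leave unreadable from compound 1 to compound 2, a step that the two limits leave unreadable from compound 1 to compound 3 and a step that the two limits leave unreadable from compound 2 to compound 3, remain unreadable in size and direction, so they give no sense of how the aryl amine end of the shared core moves the read-out. The unmeasured compound 4, `Cc1ccc(Nc2nc(C)c(C(=O)/C=C/c3ccccc3)s2)cc1`, differs from compound 1 by hydrogen in place of chloro on an aromatic carbon, at the opposite end of the molecule from the changes measured so far. Going by the values given here, none of the measured steps bears directly on this change. With every neighbour at the limit, compound 4 is expected to stay there as well, a step that the limit leaves unreadable from compound 1 to compound 4 being no more than what the data can say. Compound 4 is thus estimated at 35000 nM, in the range 10000 nM to 120000 nM.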

Compound 4, half-maximal inhibitory concentration: > 25000 nM
Compound 4 gave a limit, no number; the forecaster's own chance of this, stated with the estimate: 80%; the middle value does not contradict the limit.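

Going by these compounds alone, compound 4 also gives only a limit, so no step from compound 1 to compound 4 can be read in size or direction: the limit of > 25000 nM in this assay, at which 4 of the 4 values shown sit. The compounds shown leave open whether any of these changes to the shared core moves the read-out in this assay.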